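The source may hold more compounds than are shown below. What is called first, only, known or untested is meant among the compounds shown, and "the series" means these compounds.

Compound 2 `COC(=O)c1ccc(C)cc1OC(=O)COc1cc(O)c2c(=O)cc(-c3ccccc3)oc2c1` and compound 1 `COC(=O)c1c(Br)cc(Br)cc1OC(=O)COc1cc(O)c2c(=O)cc(-c3ccccc3)oc2c1` share one core and differ only in the aromatic ester part. In a functional assay on cells (T-cell, Mus musculus, strain BALB/c) for inhibition, read by MTT assay, with a stated time of 72 h (a lower number here means a stronger inhibitor, a higher number a weaker inhibitor), compound 2 gives 31100 nM, and compound 1 gives 45700 nM; the two values lie within the usual scatter of each other, so neither can be set apart from the other. Compound 3 `COC(=O)c1cc(F)ccc1OC(=O)COc1cc(O)c2c(=O)cc(-c3ccccc3)oc2c1` has not yet been measured. It differs from compound 2 in one place: a group of 11 heavy atoms (8 carbon, 2 oxygen, 1 fluorine; one six-membered aromatic ring of carbon only) in place of a group of 11 heavy atoms (9 carbon, 2 oxygen; one six-membered aromatic ring of carbon only), on an oxygen next to a carbonyl group. For the measured compounds named here, no step between measured compounds is known, so the step from compound 2 to compound 3 in this assay is expected to stay within the scatter: a 1.1-fold higher number from compound 2 to compound 3 (0.05 log units; within the scatter). For compound 3 the expected value is 35000 nM, within a range from 15000 nM to 80000 nM.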

Compound 3, half-maximal inhibitory concentration: 6820 nM
Compound 3: the middle estimate sits 5.1-fold (0.71 log units) above what was measured, outside the stated range (below it).
By their numbers in this assay, from the lowest: compound 3; then compounds 2 and 1 (each within the scatter of the next).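

In this assay the aromatic ester part can move the number beyond the scatter, a point compounds 1 and 2 could not show: the exchange gives a 4.6-fold lower number from compound 2 to compound 3 (0.66 log units; beyond the scatter) without any change in the count of 11 heavy atoms. The fluorine-bearing group thus stands apart from the methyl-bearing group at this place on an oxygen next to a carbonyl group. No available evidence bears on why the number moved.

The compounds shown leave open whether chlorine in place of the fluorine would give a similar number. They also leave open whether a carboxylic acid in place of the methyl ester would keep it.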